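This account rests on a few compounds, and the source may have more. Where it says the series, first, only, none or still open, it means among the compounds named here.

Compound 1 `Cc1ccc(Oc2ccc3nc(COc4cccc(C(=O)O)c4)n(C)c3n2)cc1` and compound 2 `Cn1c(COc2cccc(C(=O)O)c2)nc2ccc(Oc3ccc4c(c3)OCC4)nc21` share one core, while compound 3 `Cc1ccc(Oc2cc3c(cn2)nc(COc2cccc(C(=O)O)c2)n3C)cc1` is built from the same atoms joined differently; the difference between the two cores is not broken down here. In a physicochemical assay for lipophilicity, read by LC-MS, in phosphate buffer, measured as octanol-water partition, with a stated time of 30 min, at pH 7.4, tested at 200 mM (on this read-out higher numbers stand for higher lipophilicity and lower numbers for lower lipophilicity), compound 1 gives 1.7, compound 2 gives 1.4, and compound 3 gives 1. The change from compound 1 to compound 2 is a group of 9 heavy atoms (8 carbon, 1 oxygen; one five-membered non-aromatic ring with 1 hetero atom, one six-membered aromatic ring of carbon only) in place of a group of 7 heavy atoms (7 carbon; one six-membered aromatic ring of carbon only), on an oxygen on an aromatic ring, and it made a step of a number 0.30 log units lower from compound 1 to compound 2 (within the scatter). Compound 4 `Cn1c(COc2cccc(C(=O)O)c2)nc2cnc(Oc3ccc4c(c3)OCC4)cc21` has not yet been measured; it arises from compound 3 by the same change, (a group of 9 heavy atoms (8 carbon, 1 oxygen; one five-membered non-aromatic ring with 1 hetero atom, one six-membered aromatic ring of carbon only) in place of a group of 7 heavy atoms (7 carbon; one six-membered aromatic ring of carbon only), on an oxygen on an aromatic ring). Because the earlier instance of this change gave a number 0.30 log units lower from compound 1 to compound 2 (within the scatter), compound 4 is expected to move by a number 0.30 log units lower from compound 3 to compound 4 (within the scatter) in this assay. Compound 4 is therefore estimated at 0.7, with a likely range from 0.3 to 1.1.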

Compound 4, distribution coefficient: 0.6
Beside the measured number, compound 4's estimate is 0.10 log units above it; measured number inside the range.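

Replacing the 4-methylphenyl with the group holding a five-membered non-aromatic ring, on an oxygen on an aromatic ring, gave a number 0.40 log units lower from compound 3 to compound 4 (beyond the scatter) in this assay, while on the other core the same change gave a number 0.30 log units lower from compound 1 to compound 2 (within the scatter). Going by these compounds alone, the printed numbers run the same way on both cores, but only the step on the core of compound 3 lies beyond the usual scatter, and two pairs are too few to make a rule for the series. Nothing shown here says why the numbers moved.

Going by these compounds, it remains open how other groups on that oxygen, such as a longer alkyl chain or a chain ending in an amine, would behave. On these data alone, it is also open whether the change would carry to a third core.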